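Notes on the ring-nitrogen aryl series, compound 2 to compound 4

The source may hold more compounds than are shown below. What is called first, only, known or untested is meant among the compounds shown, and "the series" means these compounds.

Measured so far:
Compound 1 `CCN1CCN(c2c(CO)c(=O)oc3ccccc23)CC1`; in a functional assay on A-375 cells (Homo sapiens) for inhibition, read by MTT assay, with a stated time of 24 h (a lower number here means a stronger inhibitor, a higher number a weaker inhibitor), compound 1 gives > 50000 nM, which is a limit of the assay and not a number.
Compound 2 `O=c1oc2ccccc2c(N2CCN(c3ccc(F)cc3)CC2)c1CO`; in this assay compound 2 gives 24700 nM.
Compound 3 `O=c1oc2ccccc2c(N2CCN(c3ccccc3F)CC2)c1CO`; in this assay compound 3 gives 32100 nM.

Compound 1 sits at a limit, (the limit of > 50000 nM in this assay, at which 1 of the 3 values shown sits), so the steps of an at least 2.0-fold lower number from compound 1 to compound 2 (0.30 log units; that floor lies within the scatter) and an at least 1.5-fold lower number from compound 1 to compound 3 (0.19 log units; that floor lies within the scatter) are floors only and fix no size. Compound 2 stands beside compound 3 inside the scatter, the step between them being a 1.3-fold higher number from compound 2 to compound 3 (0.11 log units; within the scatter). Nothing among the three measured compounds separates one aryl group on the ring nitrogen from another beyond the scatter.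

Compound 4 `O=c1oc2ccccc2c(N2CCN(c3cccc(Cl)c3)CC2)c1CO` differs from compound 2 in one place: 3-chlorophenyl in place of 4-fluorophenyl on an amine nitrogen in a ring. For the measured compounds named here, the one measured step between two aryl groups on that nitrogen is a 1.3-fold higher number from compound 2 to compound 3 (0.11 log units; within the scatter), within the scatter, and the two steps from compound 1 are floors. No step beyond the scatter is therefore expected in this assay for compound 4, in either direction, and the expected step from compound 2 is a 1.1-fold higher number from compound 2 to compound 4 (0.04 log units; within the scatter). Compound 4 is estimated at 27000 nM, with a range from 10000 nM to 70000 nM, and with a modest chance that the assay returns only a limit.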

Compound 4, half-maximal inhibitory concentration: 40500 nM
The estimate for compound 4 lay 1.5-fold (0.18 log units) below the measured number; the range from low to high includes it.
By their numbers in this assay, from the lowest: compounds 2, 3 and 4 (each within the scatter of the next). At a limit, above all of these: compound 1.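

In this assay, 3-chlorophenyl on the amine nitrogen in a ring stands level with both fluorophenyl groups: a 1.6-fold higher number from compound 2 to compound 4 (0.21 log units; within the scatter), and a 1.3-fold higher number from compound 3 to compound 4 (0.10 log units; within the scatter). Going from either fluorophenyl group to 3-chlorophenyl changes the halogen and where it sits on the phenyl ring in a single step, and even this double change moves no value beyond the scatter, so compounds 2, 3 and 4 remain unseparated and no preference among these three aryl groups can be stated. The step of an at least 1.2-fold lower number from compound 1 to compound 4 (0.09 log units; that floor lies within the scatter) is a floor only and cannot be read as a size. The gain of an aryl group over ethyl stays unquantified, because compound 1 gives a limit and not a number: the limit of > 50000 nM in this assay, at which 1 of the 4 values shown sits.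

The compounds shown leave open whether a benzyl group, or a phenyl ring carrying a methoxy group or a carboxylic acid, on that nitrogen would give a step beyond the scatter. Also open, from the compounds shown here alone, is what the halogen alone contributes, with 3-fluorophenyl or 4-chlorophenyl being the groups that would separate the change of halogen from the change of its place on the phenyl ring.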